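A Second Methoxy Group on the Aromatic Ring

The compounds below may be only part of what the source reports. "The series", "measured", "known", "first", "only" and "open" are said of these compounds alone.

Of the compounds shown here, two sharing one core have been measured so far. Compound 1 `CCOC(=O)[C@@H]1CC(=O)c2sccc2[C@H]1c1ccc(OC)cc1` carries a single methoxy group on its aromatic ring, and in a physicochemical assay, with a stated time of 60 min, tested at 100 ug/mL (a higher number here means a stronger effect of the compound at the concentration tested, a lower number a weaker effect), compound 1 gives 34.1%. Compound 2 `CCOC(=O)[C@@H]1CC(=O)c2sccc2[C@H]1c1ccc(OCC)cc1` differs by methyl in place of hydrogen on a saturated chain carbon bound to an oxygen on an aromatic ring; in this assay compound 2 gives 38%. The step of a number 3.9 percentage points higher from compound 1 to compound 2 (within the scatter) is the only one available. Among the two numbers, compound 1 stands lowest, with compound 2 nearest, and since these two values sit within the scatter of each other, no order can be read from them.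

Compound 3 `CCOC(=O)[C@@H]1CC(=O)c2sccc2[C@H]1c1ccc(OC)c(OC)c1` has not yet been measured. It differs from compound 1 by methoxy in place of hydrogen on an aromatic carbon. Within the data shown here, the single measured step, also a small enlargement of compound 1, produced no movement beyond the scatter, so it speaks for little change here as well, though a second methoxy group is a different kind of alteration and the guide is loose. The step expected in this assay is a number 2.9 percentage points higher from compound 1 to compound 3 (within the scatter), that is, small. The estimate for compound 3 is 37%, with a range from 24% to 52%.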

Compound 3, a percentage reported as activity, at one concentration (the size of the read-out at that concentration, not a potency): 34%
Compound 3: the middle estimate sits 3 percentage points above what was measured; the measured number falls inside the stated range.
By their numbers in this assay, from the lowest: compounds 3, 1 and 2 (each within the scatter of the next).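

Compound 3 is the only one of these compounds altered directly at a carbon of the aromatic ring, with methoxy entering ortho to the existing methoxy group and meta to a large group, and the result in this assay is a number 0.1 percentage points lower from compound 1 to compound 3 (within the scatter). So at this position, a methoxy group of 2 heavy atoms, carrying 1 hydrogen-bond acceptor, leaves the read-out indistinguishable from that of compound 1, and the same holds for the other listed change to compound 1, the chain extension, which gives a number 3.9 percentage points higher from compound 1 to compound 2 (within the scatter). Nothing available explains this result, so it stands as an observation without a known cause.

These three compounds leave open whether this ring carbon would tolerate a group of a different kind just as readily, such as an amine, a carboxylic acid or a longer chain like butoxy. They also cannot tell whether a methoxy group placed on another carbon of the same ring would give a number within the scatter of compound 1, since only this one position has been shown.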